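Pyridinone N-substituent swap in the piperidine amide series

This account rests on a few compounds, and the source may have more. Where it says the series, first, only, none or still open, it means among the compounds named here.

Three compounds of the series have numbers in an ADME assay on microsomes from liver (Homo sapiens) for metabolic stability; a higher number here means faster removal of the compound, a lower number slower removal. Compound 1 `CNC(=O)CN1CCC(c2cc3c(-c4ccc(=O)n(C(C)C)c4)ccnc3[nH]2)CC1` gives 8.6 uL/min. Compound 2 `CC(C)n1cc(-c2ccnc3[nH]c(C4CCN(CC(=O)N(C)C)CC4)cc23)cnc1=O` gives 24 uL/min. Compound 3 `CN(C)C(=O)CN1CCC(c2cc3c(-c4ccc(=O)n(C5CCOCC5)c4)ccnc3[nH]2)CC1` gives 8.2 uL/min, the lowest of the three numbers; the value of compound 1 sits within the scatter of it, while compound 2 lies beyond the scatter, higher.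

The next step goes from compound 3 to compound 4 `CN(C)C(=O)CN1CCC(c2cc3c(-c4ccc(=O)n(C)c4)ccnc3[nH]2)CC1`, which is not yet measured in this assay. The change is methyl in place of oxan-4-yl on an aromatic nitrogen of a six-membered aromatic ring with 1 nitrogen, ortho to a group of 1 heavy atom and meta to a large group. The rest of the molecule, including the dimethylamide on the piperidine, is kept.

Within the data shown here, no measured pair in the set isolates this change. Compound 1, with a different group on the same aromatic nitrogen and a different amide, gives 8.6 uL/min, close to compound 3. For compound 4 the expected step is therefore small, a 1.1-fold lower number from compound 3 to compound 4 (0.04 log units; within the scatter), and not beyond the scatter. Compound 4 is estimated at 7.5 uL/min, with a range from 3.5 uL/min to 15 uL/min.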

Compound 4, intrinsic clearance in a liver preparation (reported as CLH), per the amount of preparation that the assay uses: < 3 uL/min
Compound 4 was reported as a limit; the forecaster's own chance of this, stated with the estimate: 5%; middle value at least 2.5-fold (0.39 log units) away from the limit.
By their numbers in this assay, from the lowest: compounds 3 and 1 (each within the scatter of the next); then compound 2. At a limit, below all of these: compound 4.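

In this assay, compound 4 is reported as a limit and not a number: the limit of < 3 uL/min in this assay, at which 1 of the 4 values shown sits.

Among these compounds, with the rest of the molecule held, methyl in place of oxan-4-yl on the aromatic nitrogen gives an at least 2.7-fold lower number from compound 3 to compound 4 (0.43 log units; beyond the scatter), the first step that isolates this position and shows that the group on this nitrogen can shift the number beyond the scatter. The wider exchange on the aromatic carbon gives an at least 8.0-fold lower number from compound 2 to compound 4 (0.90 log units; beyond the scatter), but it alters the ring and the group on its nitrogen together, and so does not separate the two.

From the compounds shown here alone, both steps are bounded on one side only, and their full size stays open. Also open, going by these compounds, is where ethyl or cyclopropyl on the same nitrogen would fall with the dimethylamide kept, and whether the number follows the size of that group at all.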